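The compounds below may be only part of what the source reports. "The series", "measured", "known", "first", "only" and "open" are said of these compounds alone.

In an ADME assay on microsomes from liver (Mus musculus) for metabolic stability, read by LC-MS, with a stated time of 30 min, tested at 1 uM (on this read-out lower numbers stand for a less stable compound and higher numbers for a more stable compound), compound 1 `CC(=O)N1CCN(C(=O)[C@@H]2CC[C@@H](C)N2C(=O)C2=C(C(C)C)N3C(=N[C@@](C)(c4ccc(Cl)cc4)[C@H]3c3ccc(Cl)cc3)S2)CC1` gives 13%, the lowest of the three numbers at hand. Compound 3 `CC[C@@H]1CC[C@@H](C(=O)N2CCN(C(C)=O)CC2)N1C(=O)C1=C(C(C)C)N2C(=N[C@@](C)(c3ccc(Cl)cc3)[C@H]2c2ccc(Cl)cc2)S1` stands at 38%, and compound 2 `CC[C@@H]1CC[C@@H](C(=O)N2CCN(C)CC2)N1C(=O)C1=C(C(C)C)N2C(=N[C@@](C)(c3ccc(Cl)cc3)[C@H]2c2ccc(Cl)cc2)S1` stands at 50%. Compound 4 `CC(=O)N1CCN(C(=O)[C@@H]2CC[C@@H](C)N2C(=O)C2=C(C(C)C)N3C(=N[C@@](C)(c4ccc(Cl)cc4)[C@H]3c3ccc(Cl)cc3)S2)C[C@@H]1C` differs from compound 1 in a single place: methyl in place of hydrogen on a saturated ring carbon. This is methyl in place of hydrogen on a saturated ring carbon, next to the ring atom that bears an acetyl group.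

Going by the values given here, two measured steps bear on this change, though neither occurs at that carbon. Methyl in place of hydrogen on a saturated chain carbon gave a number 25 percentage points higher from compound 1 to compound 3 (beyond the scatter). Acetyl in place of methyl on an amine nitrogen in the same ring gave a number 12 percentage points lower from compound 2 to compound 3 (beyond the scatter). Among the compounds with values here, no measured step adds a methyl to a carbon of this ring, so the size of the change remains uncertain. Going by a number 25 percentage points higher from compound 1 to compound 3 (beyond the scatter), a smaller rise in the same direction is expected, and it may not clear the scatter. The estimated change is a number 9 percentage points higher from compound 1 to compound 4 (within the scatter). The expected value for compound 4 is 22%, with an estimated range from 9% to 40%.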

Compound 4, percent of the compound remaining: 65%
The estimate for compound 4 lay 43 percentage points below the measured number; the whole stated range lies below it.
By their numbers in this assay, from the lowest: compound 1; then compound 3; then compound 2; then compound 4.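

In this assay, a methyl on a saturated ring carbon of the six-membered non-aromatic ring with 2 nitrogen, next to the ring atom that bears an acetyl group, gives a number 52 percentage points higher from compound 1 to compound 4 (beyond the scatter). This shows that a single added carbon at this ring position can produce a large step, one that exceeds the step for the methyl on the saturated chain carbon, a number 25 percentage points higher from compound 1 to compound 3 (beyond the scatter). Nothing at hand gives a reason for this rise.

The compounds shown leave open whether an ethyl group, a hydroxymethyl group or a fluorine at this ring carbon would give a similar step. They also leave open whether the ring methyl would have the same effect with the chain methyl of compound 3 present, or with the methyl on the ring nitrogen of compound 2 in place of the acetyl group.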